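Swapping one phenyl group for another on an amine nitrogen

The source may hold more compounds than are shown below. What is called first, only, known or untested is meant among the compounds shown, and "the series" means these compounds.

Values in a functional assay on ECa-109 cells for inhibition, with ECa-109 cell line (Homo sapiens) as the target, read by sulforhodamine B assay; on this read-out lower numbers stand for stronger inhibition and higher numbers for weaker inhibition:
- compound 1 `O=C1C(Nc2ccc(I)cc2)=CC(=O)c2c1nc1n2[C@H]2OC[C@@H](O)[C@H]2OC1`: 2530 nM
- compound 2 `O=C1C(NC2CCCC2)=CC(=O)c2c1nc1n2[C@H]2OC[C@@H](O)[C@H]2OC1`: > 16000 nM (a limit of the assay, not a number)
- compound 3 `Cc1ccc(NC2=CC(=O)c3c(nc4n3[C@H]3OC[C@@H](O)[C@H]3OC4)C2=O)cc1C`: 4090 nM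

Among the measured compounds shown here, of these three results, only two are true numbers, and compound 3 holds one of them. The gap between the two is small: a 1.6-fold higher number from compound 1 to compound 3 (0.21 log units; within the scatter).

The next compound, compound 4 `O=C1C(Nc2ccc(C(F)(F)F)cc2)=CC(=O)c2c1nc1n2[C@H]2OC[C@@H](O)[C@H]2OC1`, differs from compound 3 only in one group: 4-(trifluoromethyl)phenyl in place of 3,4-dimethylphenyl on an amine nitrogen. In words, this is 4-(trifluoromethyl)phenyl in place of 3,4-dimethylphenyl on an amine nitrogen.

For the measured compounds named here, the closest precedent is the small step above, which also exchanged one substituted phenyl group for another. Replacing the phenyl group with cyclopentyl gave larger steps: an at least 6.3-fold higher number from compound 1 to compound 2 (0.80 log units; beyond the scatter), and in the opposite direction, an at least 3.9-fold lower number from compound 2 to compound 3 (0.59 log units; beyond the scatter). Both of these larger steps rest on a limit rather than a number.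

Compound 4 keeps a phenyl group. Taking a 1.6-fold higher number from compound 1 to compound 3 (0.21 log units; within the scatter) as the guide, no step beyond the scatter is expected in this assay. The estimated step is a 1.4-fold lower number from compound 3 to compound 4 (0.13 log units; within the scatter). Compound 4 is expected at 3000 nM, with an estimated range of 1200 nM to 8000 nM.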

Compound 4, half-maximal inhibitory concentration: 2250 nM
Compound 4: middle estimate off by 1.3-fold (0.12 log units), on the high side, within the range that was stated.
By their numbers in this assay, from the lowest: compounds 4, 1 and 3 (each within the scatter of the next). At a limit, above all of these: compound 2.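

Three differently substituted phenyl groups on this amine nitrogen now cannot be told apart in this assay: neither 4-(trifluoromethyl)phenyl in place of 3,4-dimethylphenyl (a 1.8-fold lower number from compound 3 to compound 4 (0.26 log units; within the scatter)) nor trifluoromethyl in place of iodo (a 1.1-fold lower number from compound 1 to compound 4 (0.05 log units; within the scatter)) moves the number beyond the scatter. The difference from cyclopentyl also holds for this third phenyl group (an at least 7.1-fold lower number from compound 2 to compound 4 (0.85 log units; beyond the scatter)), so the contrast between the phenyl groups and cyclopentyl no longer depends on two examples alone. That step still rests on compound 2, which gives a limit and not a number: (the limit of > 16000 nM in this assay, at which 1 of the 4 values shown sits).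

From the compounds shown here alone, it remains open whether a plain unsubstituted phenyl group, a pyridine ring or a longer alkyl chain would fall with the phenyl groups or with cyclopentyl. Going by these compounds, it is also open whether a carboxylic acid or an amine on the phenyl ring would give a step beyond the scatter.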